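The compounds below may be only part of what the source reports. "The series", "measured", "known", "first", "only" and "open" are said of these compounds alone.

Measured compounds:
Compound 1 `CCCCCCc1cn([C@@H]2O[C@H](CO)[C@@H](O)[C@H]2O)nn1`: in a functional assay on MOLT-4 cells (Homo sapiens) (a higher number here means a weaker inhibitor, a lower number a stronger inhibitor), compound 1 gives > 200000 nM, which is a limit of the assay and not a number.
Compound 2 `COc1ccc(-c2cn([C@@H]3O[C@H](CO)[C@@H](O)[C@H]3O)nn2)cc1`: in this assay compound 2 gives 36000 nM.

Within the data shown here, compound 2 therefore stands as the only compound with a numerical value here; the other entry is a limit, as the note the limit of > 200000 nM in this assay, at which 1 of the 2 values shown sits, records. Compound 3 `OC[C@H]1O[C@@H](n2cc(-c3ccc(F)cc3)nn2)[C@H](O)[C@@H]1O` is the compound still to be measured. It is made from compound 2 by one change: fluoro in place of methoxy on an aromatic carbon. Among the measured compounds shown here, no step between two measured compounds is available to calibrate what this swap does. Both measured compounds carry the same sugar-bearing core, and the group on the six-membered ring is the only thing that has moved. The step from compound 2 to compound 3 is expected to be small, within the usual scatter, or at most a modest weakening, estimated as a 1.4-fold higher number from compound 2 to compound 3 (0.14 log units; within the scatter). Compound 3 is thus expected to give about 50000 nM in this assay, with a likely range from 15000 nM to 170000 nM.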

Compound 3, half-maximal inhibitory concentration: 171000 nM
For compound 3 the middle estimate is 3.4-fold (0.53 log units) below the measured one, outside the stated range (above it).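

In this assay, the group on the six-membered aromatic ring proves to matter: the swap of methoxy for fluoro gives a 4.8-fold higher number from compound 2 to compound 3 (0.68 log units; beyond the scatter), so methoxy gives the stronger inhibitor of this pair. The value for compound 1 is a limit of the assay and not a number, and the swap of hexyl for 4-fluorophenyl gives an at least 1.1-fold lower number from compound 1 to compound 3 (0.06 log units; that floor lies within the scatter), which does not separate these two groups. Compound 3 also reads close to the edge of what the assay reports: the limit of > 200000 nM in this assay, at which 1 of the 3 values shown sits.

From the compounds shown here alone, how an amine, a hydroxyl or a longer ether chain at this position would read in this assay stays open. What sets methoxy apart from fluoro also stays open, as these few compounds give a difference but no explanation for it.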